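A few compounds are considered here, and "the series" means these few. Any claim that something is new, unique, unknown or untested is made for them only; others in the source may bear on it.

Three compounds sharing one core were tested in a functional assay for agonist activity at G protein-coupled receptor 88 (Homo sapiens), read by HTRF and cAMP accumulation; a higher number here means that more compound is needed for the effect, a lower number that less compound is needed. Compound 1 `CC(C)C[C@H](N)CN(C(=O)[C@@H]1C[C@H]1c1ccccc1)c1ccc(-c2ccsc2)cc1` gives 1200 nM. Compound 2 `CC(C)C[C@H](N)CN(C(=O)[C@@H]1C[C@H]1c1ccccc1)c1ccc(-c2ccoc2)cc1` gives 2000 nM. Compound 3 `Cc1ccccc1-c1ccc(N(C[C@@H](N)CC(C)C)C(=O)[C@@H]2C[C@H]2c2ccccc2)cc1` gives 3400 nM, the highest of the three numbers; its gap to compound 2 lies within the scatter, while its gap to compound 1 lies beyond it. Compound 4 `CC(C)C[C@H](N)CN(C(=O)[C@@H]1C[C@H]1c1ccccc1)c1ccc(-c2ccc(C#N)cc2)cc1` has not been measured; it differs from compound 3 by 4-cyanophenyl in place of 2-methylphenyl on an aromatic carbon. Two measured steps end at compound 3 and so bear on this change: a 2.8-fold higher number from compound 1 to compound 3 (0.45 log units; beyond the scatter) and a 1.7-fold higher number from compound 2 to compound 3 (0.23 log units; within the scatter). In both, putting 2-methylphenyl in place of thiophen-3-yl or furan-3-yl raised the number, modestly at most. For the measured compounds named here, no measured step exchanges 2-methylphenyl for another group, and none brings in a nitrile, so there is no direct precedent. In this assay a change no larger than the scatter is therefore expected, and the estimated step is a 1.1-fold lower number from compound 3 to compound 4 (0.05 log units; within the scatter). Compound 4 is expected to give about 3000 nM, with a range from 1000 nM to 9000 nM.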

Compound 4, half-maximal effective concentration: 670 nM
Estimate against measurement, compound 4: 4.5-fold (0.65 log units) above, and the stated range ends above it.
By their numbers in this assay, from the lowest: compounds 4, 1, 2 and 3 (each within the scatter of the next, the first and the last beyond it).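

Changing the ring at this position can lower the number as well as raise it: in this assay 4-cyanophenyl in place of 2-methylphenyl gives a 5.1-fold lower number from compound 3 to compound 4 (0.71 log units; beyond the scatter) and 4-cyanophenyl in place of furan-3-yl gives a 3.0-fold lower number from compound 2 to compound 4 (0.47 log units; beyond the scatter). A six-membered aromatic ring here therefore does not by itself give a high number, since 4-cyanophenyl in place of thiophen-3-yl gives a 1.8-fold lower number from compound 1 to compound 4 (0.25 log units; within the scatter) and leaves those two compounds unordered. Nothing shown explains why this change has the effect it does.

The step from compound 3 to compound 4 removes a methyl and adds a nitrile at a different place on the ring, so the two changes cannot be told apart. Plain phenyl, 4-methylphenyl and 2-cyanophenyl would separate them, and whether other groups on the ring could bring the number lower still remains open.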